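A few compounds are considered here, and "the series" means these few. Any claim that something is new, unique, unknown or untested is made for them only; others in the source may bear on it.

Compounds measured so far:
- compound 1 `CC1CC(=O)N(C(C)C(=O)N2CCN(c3cccc(Cl)c3)CC2)C1=O`, 13.6 mg/kg
- compound 2 `CC(C(=O)N1CCN(c2ccccc2)CC1)N1C(=O)CC(C)(C)C1=O`, "not determined" (no result reported)
- compound 3 `CC(C(=O)N1CCN(c2cccc(Cl)c2)CC1)N1C(=O)CC(C)(C)C1=O`, 19.8 mg/kg

In a functional assay on the whole organism (strain Swiss) with Mus musculus as the target, with a stated time of 0.25 h (on this read-out higher numbers stand for an effect only at larger amounts of compound and lower numbers for an effect already at smaller amounts), compound 3 gives 19.8 mg/kg, the highest of the two numbers available, while its nearest neighbour, compound 1, gives 13.6 mg/kg in this assay. Among the measured compounds shown here, the two differ by a 1.5-fold higher number from compound 1 to compound 3 (0.16 log units; within the scatter), a step that lies within the scatter, and compound 2 returned no result in this assay, so only two numbers anchor the series.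

Compound 4 `CC(C(=O)N1CCN(c2cccc(C(F)(F)F)c2)CC1)N1C(=O)CC(C)(C)C1=O` is not yet measured. It differs from compound 3 by trifluoromethyl in place of chloro on an aromatic carbon. For the measured compounds named here, none of the measured steps touches this position: the only step with numbers on both sides, from compound 1 to compound 3, concerns a methyl on a saturated ring carbon and says nothing about the aromatic substituent. Going by the values given here, the single change of an aromatic group between compounds 2 and 3 cannot be read. Compound 2 has no number. Among the compounds with values here, with no bearing step, no shift beyond the scatter is expected in this assay.

Compound 4 is therefore expected to give about 22 mg/kg in this assay, with a range of 8 mg/kg to 60 mg/kg. The expected step from compound 3 is a 1.1-fold higher number from compound 3 to compound 4 (0.05 log units; within the scatter).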

Compound 4, dose for half-maximal effect: 29 mg/kg
Compound 4: middle estimate off by 1.3-fold (0.12 log units), on the low side; the range from low to high includes it.
By their numbers in this assay, from the lowest: compounds 1, 3 and 4 (each within the scatter of the next, the first and the last beyond it).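

Among the compounds shown here, this is the first step with numbers on both sides at this aromatic carbon, meta to a large group. In this assay, the exchange of chloro for trifluoromethyl (a 1.5-fold higher number from compound 3 to compound 4 (0.17 log units; within the scatter)) replaces one heavy atom with four, adds no hydrogen-bond donor or acceptor, and leaves the two compounds within the scatter of each other, so this pair gives no sign that the read-out depends on which of these two groups sits here. Nothing measured explains this outcome or assigns any property to either group.

Compound 2, which carries no group on this ring, has no number, so the steps that would set hydrogen against chloro or trifluoromethyl here cannot be read, and the compounds shown do not tell whether either group matters compared with none. They also leave open whether a group of another kind on this aromatic carbon, such as an amine, a carboxylic acid or a longer alkyl chain, would shift the number beyond the scatter.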